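Para-substituent series on the shared sulfonyl hydrazide core

The source may report more compounds than this note shows. Statements on the series, on what has been measured and on what is new or still open speak of the compounds shown alone.

Measured compounds:
- compound 1, `CC(=O)Nc1ccc(S(=O)(=O)NNc2ccc(C)cc2)cc1`: 1170 nM
- compound 2, `CC(=O)Nc1ccc(S(=O)(=O)NNc2ccc(C#N)cc2)cc1`: 1390 nM
- compound 3, `CC(=O)Nc1ccc(S(=O)(=O)NNc2ccc(F)cc2)cc1`: 609 nM

All three were run in an assay on HeLa cells for inhibition of Indoleamine 2,3-dioxygenase 1 (Homo sapiens), read by spectrophotometry, with a stated time of 24 h; a higher number here means that more compound is needed for the effect, a lower number that less compound is needed. Compound 3 gives the lowest number of the three. Its distance from compound 1 is a 1.9-fold lower number from compound 1 to compound 3 (0.28 log units; within the scatter), and from compound 2 it is a 2.3-fold lower number from compound 2 to compound 3 (0.36 log units; beyond the scatter); only the latter lies beyond the scatter. Within the data shown here, the whole series so far spans a narrow band.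

Compound 4, `CC(=O)Nc1ccc(S(=O)(=O)NNc2ccc(Br)cc2)cc1`, is the next member. The change from compound 3 is bromo in place of fluoro on an aromatic carbon. Among the measured compounds shown here, no measured step swaps one halogen for another, so the bearing steps are indirect: the exchange of methyl for fluoro, a 1.9-fold lower number from compound 1 to compound 3 (0.28 log units; within the scatter), and of cyano for fluoro, a 2.3-fold lower number from compound 2 to compound 3 (0.36 log units; beyond the scatter). Both show that varying the group at this place moves the number only modestly. Bromo is therefore expected to leave compound 4 near the band already seen, most likely a small step upward, a 1.5-fold higher number from compound 3 to compound 4 (0.17 log units; within the scatter), and a result beyond the scatter is not expected. The estimate for compound 4 is 900 nM, within 400 nM to 2000 nM.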

Compound 4, half-maximal effective concentration: 85 nM
For compound 4 the middle estimate is 11-fold (1.02 log units) above the measured one, outside the stated range (below it).
By their numbers in this assay, from the lowest: compound 4; then compounds 3, 1 and 2 (each within the scatter of the next, the first and the last beyond it).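

Among these compounds, the step of a 7.2-fold lower number from compound 3 to compound 4 (0.86 log units; beyond the scatter) shows that this position is more sensitive than the earlier compounds suggested, since no earlier exchange here left the narrow band. Bromo also separates from the other groups, with a 16-fold lower number from compound 2 to compound 4 (1.21 log units; beyond the scatter) and a 14-fold lower number from compound 1 to compound 4 (1.14 log units; beyond the scatter) as the largest steps in the series, so compound 4 gives the lowest number of the four. No available evidence bears on why bromo and fluoro differ so much at this place.

Chloro and iodo at the same place would show whether the drop runs along the halogens or belongs to bromo alone. As far as these compounds go, whether a methoxy group, an amine or a carboxylic acid at this place would fit the same picture stays open, as does whether the bromo effect holds with changes elsewhere on the shared core.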